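Adding an Ethyl Branch Back onto Compound 2

The compounds below may be only part of what the source reports. "The series", "measured", "known", "first", "only" and "open" are said of these compounds alone.

Compound 1 `CCCCc1cnc(C(CCC)Cc2ccc(-c3ccccc3C(=O)O)cc2)[nH]1`: 1180 nM
Compound 2 `CCCCc1cnc(CCc2ccc(-c3ccccc3C(=O)O)cc2)[nH]1`: 2710 nM

In an in vitro functional assay on cells for agonist activity at Bombesin receptor subtype-3 (Homo sapiens), read by luminescence and calcium flux (on this read-out higher numbers stand for an effect only at larger amounts of compound and lower numbers for an effect already at smaller amounts), compound 2 stands highest of the two numbers; its nearest neighbour is compound 1, a modest gap that lies beyond the scatter. Compound 3 `CCCCc1cnc(C(CC)Cc2ccc(-c3ccccc3C(=O)O)cc2)[nH]1` differs from compound 2 by ethyl in place of hydrogen on a saturated chain carbon bound to an aromatic carbon and a saturated chain carbon. Within the data shown here, the only measured step that bears on this is a 2.3-fold higher number from compound 1 to compound 2 (0.36 log units; beyond the scatter), which removed a longer branch at the same place. Compound 3 puts a shorter branch back, so a lower number in this assay is expected, of similar or slightly smaller size. For compound 3 the estimate is 1400 nM, between 700 nM and 2800 nM, a step of a 1.9-fold lower number from compound 2 to compound 3 (0.29 log units; within the scatter).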

Compound 3, half-maximal effective concentration: 2720 nM
Compound 3: the middle estimate sits 1.9-fold (0.29 log units) below what was measured; low and high end bracket the measured number.
By their numbers in this assay, from the lowest: compound 1; then compounds 2 and 3 (each within the scatter of the next).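

In this assay ethyl on this saturated chain carbon gives a 1.0-fold higher number from compound 2 to compound 3 (0.00 log units; within the scatter) and so does not set the two compounds apart, although propyl at the same carbon did. Going from propyl to ethyl gives a 2.3-fold higher number from compound 1 to compound 3 (0.36 log units; beyond the scatter) and shows that among these three compounds the length of the branch matters here, not merely having one. Nothing available explains this difference. Still open, as far as these compounds go, is whether a longer chain such as butyl would bring the number lower than propyl does. Also open, from the compounds shown here alone, is how an amine or a hydroxyl group on this carbon would read.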